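The source may report more compounds than this note shows. Statements on the series, on what has been measured and on what is new or still open speak of the compounds shown alone.

Of the compounds shown here, three from this study share one core and have been tested in a functional assay on the whole organism (strain Swiss albino) for inhibition, with Mus musculus as the target, in the formalin test, with stated times of 30 min and 5 min, at a dose of 100 mg/kg; on this read-out lower numbers stand for less inhibition and higher numbers for more inhibition at the one dose given (going by the name of the read-out). Compound 1, `CCN1CCc2c(c(C)nn2C(=O)Nc2cccc(C(F)(F)F)c2)C1`, gives 4.4%. Compound 2, `CCN1CCc2c(c(C(C)(C)C)nn2C(=O)Nc2ccc(C)cc2C)C1`, gives 15.7%, and compound 3, `CCN1CCc2c(c(C(C)(C)C)nn2C(=O)Nc2cc(C)ccc2F)C1`, gives 7%. On these numbers compound 1 stands at the bottom: compound 3 lies within the usual scatter of it, while compound 2 lies beyond that scatter. Going by the values given here, the one step among the measured pairs, a number 8.7 percentage points lower from compound 2 to compound 3 (within the scatter), changes only the aryl group on the amide nitrogen and stays within the scatter.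

Compound 4, `CCN1CCc2c(c(C(C)(C)C)nn2C(=O)Nc2cccc(C(F)(F)F)c2)C1`, carries the same aryl group as compound 1; the change is tert-butyl in place of methyl on an aromatic carbon. Among the compounds with values here, no measured step makes this particular exchange, so nothing directly shows its effect. What is known is that compound 2, which carries the tert-butyl group, sits at 15.7%, that compound 3, which also carries the tert-butyl group, sits at 7%, and that compound 1 with the methyl group sits at 4.4%. Taken together these point to a small step at most, and so the expected step of a number 3.6 percentage points higher from compound 1 to compound 4 (within the scatter) lies within the scatter. Compound 4 is therefore estimated at 8%, with a likely range from 0% to 20%.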

Compound 4, a percentage reported as inhibition, in the whole organism at one dose (the size of the read-out at that dose, not a potency): 2.6%
Beside the measured number, compound 4's estimate is 5.4 percentage points above it, within the range that was stated.
By their numbers in this assay, from the lowest: compounds 4, 1, 3 and 2 (each within the scatter of the next, the first and the last beyond it).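

In this assay, going by these compounds alone, this is the first direct reading of the exchange at this position, with the aryl group on the amide nitrogen held the same: tert-butyl in place of methyl on an aromatic carbon of the five-membered ring gives a number 1.8 percentage points lower from compound 1 to compound 4 (within the scatter). Four heavy atoms in place of one at this carbon therefore leave the number within the scatter, at least with this aryl group. The tert-butyl group alone also does not set the level of the series: compound 4 gives 2.6% while compound 2 gives 15.7% with the same tert-butyl group, and these two compounds differ only in the aryl group, but no available information explains any of these numbers.

The compounds shown leave open whether methyl and tert-butyl would also read alike with the aryl group of compound 2 or compound 3, where the exchange has no measured pair. They also leave open how this carbon would respond to a group of another kind, such as an amine, a carboxylic acid or a longer chain.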